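Trifluoromethoxy to hydroxy: a working estimate

The source may report more compounds than this note shows. Statements on the series, on what has been measured and on what is new or still open speak of the compounds shown alone.

In a functional assay on ZR-75-1 cells (Homo sapiens) for inhibition, read by sulforhodamine B assay (a higher number here means a weaker inhibitor of growth, a lower number a stronger inhibitor of growth), compound 1 (`FC(F)(F)c1ccc(-c2ccc(-c3ccc(-c4nc5ccccc5[nH]4)cc3)cc2)cc1`) gives 48300 nM as its read-out. Going by the values given here, compound 2 (`FC(F)(F)Oc1ccc(-c2ccc(-c3ccc(-c4nc5ccccc5[nH]4)cc3)cc2)cc1`) gives 100000 nM as the higher of the two numbers so far. The next structure, compound 3 (`Oc1ccc(-c2ccc(-c3ccc(-c4nc5ccccc5[nH]4)cc3)cc2)cc1`), differs from compound 2 as follows (hydrogen in place of trifluoromethyl on an oxygen on an aromatic ring): hydrogen in place of trifluoromethyl on an oxygen on an aromatic ring, or trifluoromethoxy to hydroxy. Among the compounds with values here, only one measured step bears on this, and no measured compound carries hydroxy, so support is thin. Because a 2.1-fold higher number from compound 1 to compound 2 (0.32 log units; beyond the scatter) accompanied the arrival of trifluoromethoxy, a modest move to a lower number is expected once that group leaves. The estimated step in this assay is a 2.5-fold lower number from compound 2 to compound 3 (0.40 log units; beyond the scatter) with wide uncertainty. For compound 3 the estimated value is 40000 nM with an expected range from 10000 nM to 100000 nM in this assay.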

Compound 3, concentration for 50% growth inhibition: 100000 nM
For compound 3 the middle estimate is 2.5-fold (0.40 log units) below the measured one, within the range that was stated.
By their numbers in this assay, from the lowest: compound 1; then compounds 2 and 3 (each within the scatter of the next).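

In this assay, hydrogen in place of trifluoromethyl on the oxygen on an aromatic ring gives (no change at the digits printed from compound 2 to compound 3 (within the scatter)). At this place, then, the read-out does not separate trifluoromethoxy from hydroxy, although these two groups differ by trifluoromethyl's 4 heavy atoms. Hydroxy in place of trifluoromethyl on an aromatic carbon gives (a 2.1-fold higher number from compound 1 to compound 3 (0.32 log units; beyond the scatter)), so the two groups that attach through oxygen read alike and both stand apart from trifluoromethyl, though only modestly.

Going by these compounds, whether methyl on that oxygen, or an amine or a carboxylic acid in place of hydroxy, would read apart from these values remains open. No measured property accompanies these numbers, and no explanation for them can be offered.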